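Adding a benzyloxy group to compound 2

This account rests on a few compounds, and the source may have more. Where it says the series, first, only, none or still open, it means among the compounds named here.

Two small compounds set the starting point. In a functional assay on a cell-free system (plasma, Homo sapiens) for inhibition, with Plasma (Rattus norvegicus) as the target (a higher number here means a weaker inhibitor, a lower number a stronger inhibitor), compound 1 `O=c1cc(N2CCNCC2)oc2ccccc12` gives 240000 nM. Its close relative, compound 2 `O=c1cc(N2CCNCC2)c2ccccc2o1`, gives 250000 nM, and the two values lie within the usual scatter of each other. Neither compound can therefore be ranked above the other, and both sit at the same level on this scale.

The next compound, compound 3 `O=c1cc(N2CCNCC2)c2c(OCc3ccccc3)cccc2o1`, keeps the core of compound 2 and carries one change: benzyloxy in place of hydrogen on an aromatic carbon. In words, benzyloxy stands in place of hydrogen on an aromatic carbon. This adds a sizeable group to a small molecule. For the measured compounds named here, no pair of measured compounds shows what such a change does in this assay, so any forecast here is uncertain. The direction is a judgement: a moderate move towards a stronger inhibitor seems more likely than no change, and a loss of activity cannot be excluded. The expected change is a 3.1-fold lower number from compound 2 to compound 3 (0.49 log units; beyond the scatter). For compound 3, the estimated value is 80000 nM, with an expected range from 15000 nM to 300000 nM.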

Compound 3, half-maximal inhibitory concentration: 429000 nM
Compound 3: the middle estimate sits 5.4-fold (0.73 log units) below what was measured; measured number outside the range, above it.
By their numbers in this assay, from the lowest: compounds 1, 2 and 3 (each within the scatter of the next).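

Putting benzyloxy in place of hydrogen on this aromatic carbon, ortho to a fused ring and meta to a fused ring, gives a 1.7-fold higher number from compound 2 to compound 3 (0.23 log units; within the scatter) in this assay. For the compounds shown here, this is the first measured step for the series, and it shows that a group of 8 heavy atoms, including a six-membered aromatic ring, can sit at this position without compound 3 being told apart from compound 2 on this scale, so this change brings no measurable gain in inhibition and no measurable loss. Nothing available here accounts for this result.

As far as these compounds go, one change at one position cannot show whether the position responds to substituents in general, so it remains open whether a smaller methoxy group, a basic amine, a carboxylic acid or a longer chain ending in a phenyl ring would move the number beyond the scatter. From the compounds shown here alone, it is also open whether benzyloxy would behave in the same way on another aromatic carbon of the core, or on the core of compound 1.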